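Piperazine aryl swap on two naphthamide cores

A few compounds are considered here, and "the series" means these few. Any claim that something is new, unique, unknown or untested is made for them only; others in the source may bear on it.

Among the compounds with values here, the three compounds measured so far share a propyl-linked naphthamide–piperazine skeleton and were tested in an assay on HEK293 cells for inhibition of sodium-dependent dopamine transporter (Homo sapiens), read by scintillation counting; on this read-out lower numbers stand for stronger inhibition and higher numbers for weaker inhibition. Compound 1 `O=C(NCCCN1CCN(c2ncccn2)CC1)c1cccc2ccccc12` carries a pyrimidin-2-yl on the piperazine nitrogen; in this assay compound 1 reaches only the limit > 10000 nM. Compound 2 `O=C(NCCCN1CCN(c2cccc(Cl)c2Cl)CC1)c1cccc2ccccc12` is obtained through (2,3-dichlorophenyl in place of pyrimidin-2-yl on an amine nitrogen in a ring); in this assay compound 2 likewise stops at the limit > 10000 nM. The step between them is therefore a step that the two limits leave unreadable from compound 1 to compound 2. Compound 3 `O=C(NCCCN1CCN(c2ncccn2)CC1)c1ccc2ccccc2c1` has the same atoms as compound 1 joined differently; how the two cores differ is not broken down here. In this assay compound 3 also sits at the limit > 10000 nM. All three values rest on the same line: the limit of > 10000 nM in this assay, at which 3 of the 3 values shown sit.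

Compound 4 `O=C(NCCCN1CCN(c2cccc(Cl)c2Cl)CC1)c1ccc2ccccc2c1` is not yet measured and arises from compound 3 by 2,3-dichlorophenyl in place of pyrimidin-2-yl on an amine nitrogen in a ring, the same change as that from compound 1 to compound 2. Since that earlier step is unreadable, and since compound 3 gives only a limit, the expected step in this assay is a step that the limit leaves unreadable from compound 3 to compound 4, an estimate that rests on compound 3 at > 10000 nM and on compound 2 at > 10000 nM. In this assay compound 4 is expected to give about 15000 nM, most likely again as a limit, somewhere between 3000 nM and 60000 nM.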

Compound 4, half-maximal inhibitory concentration: > 10000 nM
Compound 4: only a limit was reported; the forecaster's own chance of this, stated with the estimate: 75%; the middle value lies beyond the limit too.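

In this assay compound 4 gives only a limit, > 10000 nM. The steps to compound 4 from compound 3 and from compound 2 therefore cannot be read, and the result joins the others on one line: the limit of > 10000 nM in this assay, at which 4 of the 4 values shown sit.

The compounds shown leave open whether either change, of the group on the ring nitrogen or of the naphthalene attachment, alters inhibition at all.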